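Replacing trifluoromethyl with methyl in compound 3

The compounds below may be only part of what the source reports. "The series", "measured", "known", "first", "only" and "open" are said of these compounds alone.

Measured in a functional assay on A549 cells (Homo sapiens) for inhibition, read by MTT assay, with a stated time of 48 h; a higher number here means a weaker inhibitor, a lower number a stronger inhibitor:
Compound 1 `COc1cc(-c2nccn3cc(-c4ccc(F)cc4)nc23)cc(OC)c1OC`: 137 nM
Compound 2 `COc1cc(-c2nccn3cc(-c4ccc5[nH]ccc5c4)nc23)cc(OC)c1OC`: 154 nM
Compound 3 `COc1cc(-c2nccn3cc(-c4ccc(C(F)(F)F)cc4)nc23)cc(OC)c1OC`: > 10000 nM (a limit, not a number)

Compound 3 gives > 10000 nM, which is a limit of the assay and not a number. Compound 3 alone sits at the limit of > 10000 nM in this assay, at which 1 of the 3 values shown sits.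

Compound 4 `COc1cc(-c2nccn3cc(-c4ccc(C)cc4)nc23)cc(OC)c1OC` keeps the shared core and carries methyl in place of trifluoromethyl on an aromatic carbon, para to a large group: methyl in place of trifluoromethyl on an aromatic carbon. The same difference reads 4-(trifluoromethyl)phenyl to 4-methylphenyl.

Within the data shown here, no measured step makes this exact change, but two bear on it. Trifluoromethyl in place of fluoro gave a large step, an at least 72-fold higher number from compound 1 to compound 3 (1.86 log units; beyond the scatter). The move from the indolyl compound was similarly large, an at least 64-fold higher number from compound 2 to compound 3 (1.81 log units; beyond the scatter). By contrast, a 1.1-fold higher number from compound 1 to compound 2 (0.05 log units; within the scatter), so two quite different groups at this place gave matching results in this assay. Compound 3 is therefore the outlier among the three, and removing its trifluoromethyl is expected to move the number down, towards a stronger inhibitor. The expected change is an at least 20-fold lower number from compound 3 to compound 4 (1.30 log units; beyond the scatter), a rough figure that rests on a limit.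

Compound 4 is estimated at 500 nM, with an expected range of 120 nM to 6000 nM.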

Compound 4, half-maximal inhibitory concentration: 135 nM
For compound 4 the middle estimate is 3.7-fold (0.57 log units) above the measured one; measured number inside the range.
By their numbers in this assay, from the lowest: compounds 4, 1 and 2 (each within the scatter of the next). At a limit, above all of these: compound 3.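

In this assay, among these compounds, the single change from trifluoromethyl to methyl, on an aromatic carbon para to a large group, gives an at least 74-fold lower number from compound 3 to compound 4 (1.86 log units; beyond the scatter), which ties the loss seen in compound 3 to the trifluoromethyl group and shows that a one-carbon group at this place can match the earlier compounds. Methyl sits level with both earlier groups, with a 1.0-fold lower number from compound 1 to compound 4 (0.01 log units; within the scatter) and a 1.1-fold lower number from compound 2 to compound 4 (0.06 log units; within the scatter), so fluoro, 1H-indol-5-yl and methyl all read alike here, and among the four compounds only compound 3 goes against this. The reading for compound 3 is a limit of the assay and not a number: the limit of > 10000 nM in this assay, at which 1 of the 4 values shown sits.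

What the compounds shown leave open is why trifluoromethyl alone departs from the other three groups, since the data give no reason for it. They also leave open how far this tolerance extends, for instance to chloro, methoxy, an amine, a carboxylic acid or a longer chain such as propyl at the same place.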